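The compounds below may be only part of what the source reports. "The series", "measured", "known", "first", "only" and "open" are said of these compounds alone.

Of the compounds shown here, three of a shared core have been tested in an assay on isolated protein for inhibition of DNA topoisomerase 1 (Homo sapiens), with a stated time of 30 min, tested at 100 uM; on this read-out higher numbers stand for a stronger effect at the one concentration tested and lower numbers for a weaker effect. Compound 1, `COc1ccc(-c2cc3ccccc3c(-c3ccc(OC)cc3)n2)cc1`, gives 0% in this assay. Compound 2, `COc1ccc(-c2cc3cc(C)ccc3c(-c3cccc(N)c3)n2)c(C)c1`, gives 79.7%. Compound 3, `COc1ccc(-c2cc3cc(C)ccc3c(-c3cccc(O)c3)n2)cc1OC`, gives 1.7%. Among these three numbers compound 3 holds the second highest; its nearest neighbour is compound 1, whose value lies within the scatter of its own, so the two cannot be told apart, while compound 2 lies beyond the scatter, far above it. Going by the values given here, compound 2 differs from compound 3 in more than one place, so no single structural step can be drawn between them.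

Compound 4, `COc1ccc(-c2nc(-c3ccc(OC)c(OC)c3)cc3cc(C)ccc23)cc1`, has not yet been measured. It differs from compound 3 in a single place: 4-methoxyphenyl in place of 3-hydroxyphenyl on an aromatic carbon. Among the compounds with values here, no measured pair shows this exact change. Because compound 1, which also carries a 4-methoxyphenyl group, gives 0%, compound 4 is expected to stay near the low end, with a step of a number 0.3 percentage points higher from compound 3 to compound 4 (within the scatter) that is not expected to go beyond the scatter. The estimate for compound 4 in this assay is 2%, with a range from 0% to 12%.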

Compound 4, a percentage reported as inhibition, at one concentration (the size of the read-out at that concentration, not a potency): 2.3%
Compound 4: middle estimate off by 0.3 percentage points, on the low side; low and high end bracket the measured number.
By their numbers in this assay, from the lowest: compounds 1, 3 and 4 (each within the scatter of the next); then compound 2.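

In this assay replacing 3-hydroxyphenyl with 4-methoxyphenyl on the aromatic carbon next to the ring nitrogen gives a number 0.6 percentage points higher from compound 3 to compound 4 (within the scatter) and so cannot be told apart from no change at all. Going by these compounds alone, this is the first direct look at this position, and on this read-out the two groups are interchangeable, though only at a level where little effect is seen. No supporting data are available to explain this outcome.

A swap between two groups that both give low numbers says little about how much this position can alter the effect. From the compounds shown here alone, whether a quite different group on this carbon, such as a carboxylic acid or a longer chain ending in an amine, would lift the read-out remains open.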